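The source may hold more compounds than are shown below. What is called first, only, known or untested is meant among the compounds shown, and "the series" means these compounds.

Working notes on the series. In a functional assay on HepG2 cells (Homo sapiens) for antiproliferative activity, read by CCK-8 assay, with a stated time of 48 h (on this read-out higher numbers stand for weaker inhibition and lower numbers for stronger inhibition), compound 1 (`COc1ccc(/C=C\c2cc(OC)c(OC)c(OC)c2)cc1OCc1ccc(CN2CC[C@H](C(=O)O)C2)cc1`) gives 6400 nM and compound 2 (`COc1ccc(/C=C\c2cc(OC)c(OC)c(OC)c2)cc1OCc1ccc(CO)cc1`) gives 2400 nM. Compound 3 (`COc1ccc(/C=C\c2cc(OC)c(OC)c(OC)c2)cc1OCc1ccc(CN2CC(C(=O)O)C2)cc1`) stands at > 10000 nM, which is a limit and not a number (the limit of > 10000 nM in this assay, at which 1 of the 3 values shown sits). Compound 4 (`COc1ccc(/C=C\c2cc(OC)c(OC)c(OC)c2)cc1OCc1ccc(CN2CC[C@@H](C(=O)O)C2)cc1`) differs from compound 3 in one place, on a saturated chain carbon bound to an aromatic carbon: 3-carboxypyrrolidin-1-yl in place of 3-carboxyazetidin-1-yl on a saturated chain carbon bound to an aromatic carbon. Compound 1 also carries a 3-carboxypyrrolidin-1-yl group, so the closest evidence is an at least 1.5-fold higher number from compound 1 to compound 3 (0.19 log units; that floor lies within the scatter), read in reverse. an at least 4.1-fold higher number from compound 2 to compound 3 (0.61 log units; beyond the scatter) and a 2.7-fold lower number from compound 1 to compound 2 (0.43 log units; beyond the scatter) bear on it less directly, as both involve hydroxy. A modest fall in the number is therefore expected in this assay, and the expected step is an at least 1.6-fold lower number from compound 3 to compound 4 (0.22 log units; that floor lies within the scatter). For compound 4 the estimate is 6000 nM, with an expected range of 2500 nM to 14000 nM.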

Compound 4, half-maximal inhibitory concentration: 2300 nM
For compound 4 the middle estimate is 2.6-fold (0.42 log units) above the measured one, outside the stated range (below it).
By their numbers in this assay, from the lowest: compounds 4 and 2 (each within the scatter of the next); then compound 1. At a limit, above all of these: compound 3.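

The 3-carboxypyrrolidin-1-yl group in place of 3-carboxyazetidin-1-yl gives an at least 4.3-fold lower number from compound 3 to compound 4 (0.63 log units; beyond the scatter), and in place of hydroxy it gives a 1.0-fold lower number from compound 2 to compound 4 (0.02 log units; within the scatter), so with this group the position reads level with hydroxy. Compound 3 stands at a limit, so the first of these steps is only a floor: the limit of > 10000 nM in this assay, at which 1 of the 4 values shown sits. The step of a 2.8-fold lower number from compound 1 to compound 4 (0.44 log units; beyond the scatter) rests on the ring stereocentre alone, drawn S in the former and R in the latter, because of this: the fact that compounds 1 and 4 differ only in the configuration as drawn.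

The compounds shown leave open whether this stereocentre preference persists with a methyl ester in place of the carboxylic acid.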